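Hydrazide variation on an adenosine receptor ligand: predicting compound 3

This account rests on a few compounds, and the source may have more. Where it says the series, first, only, none or still open, it means among the compounds named here.

Compound 1, `CCNC(=O)[C@H]1O[C@@H](n2cnc3c(NNC(=O)c4cccs4)nc(Cl)nc32)[C@H](O)[C@@H]1O`, gives 737 nM in an assay on CHO cells for displacement of a labelled ligand from adenosine receptor A1 (Homo sapiens); a higher number here means a weaker inhibitor, a lower number a stronger inhibitor.
Compound 2, `CCNC(=O)[C@H]1O[C@@H](n2cnc3c(NNC(=O)c4ccc[nH]4)nc(Cl)nc32)[C@H](O)[C@@H]1O`, gives 610 nM in this assay.

Within the data shown here, compound 2 stands as the lower of the two numbers measured so far in this assay, with compound 1 as its only neighbour, and the gap between them is small: a 1.2-fold lower number from compound 1 to compound 2 (0.08 log units; within the scatter). The two compounds share the same core and differ only in the ring attached to the hydrazide carbonyl.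

Compound 3, `CCNC(=O)[C@H]1O[C@@H](n2cnc3c(NNC(=O)c4cc(-c5ccccc5)on4)nc(Cl)nc32)[C@H](O)[C@@H]1O`, has not yet been measured in this assay. It differs from compound 2 in one place: 5-phenyl-1,2-oxazol-3-yl in place of 1H-pyrrol-2-yl on a carbonyl carbon. The entering group is considerably larger than the one it replaces and carries no hydrogen-bond donor.

Among the measured compounds shown here, the only measured step, from compound 1 to compound 2, swaps one small five-membered ring for another and lies within the scatter, so it says little about a move to a much bigger two-ring group. For the measured compounds named here, no measured pair shows what such growth does here. The expectation for compound 3 is therefore a step of a 1.2-fold higher number from compound 2 to compound 3 (0.09 log units; within the scatter), with wide uncertainty, and an estimated value of 750 nM, ranging from 200 nM to 3000 nM.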

Compound 3, inhibition constant: > 5000 nM
Compound 3: no number, only a limit; the forecaster's own chance of this, stated with the estimate: 5%; middle value at least 6.6-fold (0.82 log units) away from the limit.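

Compound 3 gives no number in this assay, only a limit: the limit of > 5000 nM in this assay, at which 1 of the 3 values shown sits.

Until now the place on the carbonyl carbon looked insensitive, as the swap between thiophen-2-yl and 1H-pyrrol-2-yl stayed within the scatter, but the group there clearly can matter: 5-phenyl-1,2-oxazol-3-yl gives an at least 8.1-fold higher number from compound 2 to compound 3 (0.91 log units; beyond the scatter), and against the thiophene compound it gives an at least 6.7-fold higher number from compound 1 to compound 3 (0.83 log units; beyond the scatter). Both steps lie beyond the scatter, so among the compounds shown, this position accepts the two single-ring groups with similar results, while the two-ring group gives a much weaker inhibitor.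

On these data alone, what remains open is which part of the entering group is responsible, as compound 3 changes the five-membered ring and adds a phenyl ring in the same step. A plain 1,2-oxazol-3-yl without the phenyl would separate these two changes, and a phenyl ring set directly on the carbonyl carbon would show how a six-membered ring alone behaves at this place.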